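This account rests on a few compounds, and the source may have more. Where it says the series, first, only, none or still open, it means among the compounds named here.

Compound 1 `COc1ccccc1OCc1cc(C)nc(-c2ccccn2)n1`: 2000 nM
Compound 2 `COc1cccc(OCc2cc(C)nc(-c3ccccn3)n2)c1`: 2000 nM

Both compounds were tested in a functional assay on cells for antagonist activity at Free fatty acid receptor 1 (Homo sapiens), read by TR-FRET and inositol phosphate accumulation, with a stated time of 2 h; on this read-out higher numbers stand for weaker inhibition and lower numbers for stronger inhibition. Compound 1 gives 2000 nM, and compound 2 gives 2000 nM, so compound 2 stands level with compound 1 at the digits shown; the gap lies within the usual scatter, and neither can be called the stronger inhibitor. Moving the methoxy group around the ring thus left the read-out unchanged here.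

Compound 3 `Cc1cc(COc2cccc(S(C)(=O)=O)c2)nc(-c2ccccn2)n1` has not yet been measured. It differs from compound 2 in one place: methylsulfonyl in place of methoxy on an aromatic carbon. Among the compounds with values here, no step between two measured compounds shows what this exchange does in this assay, so the expectation rests only on the two values above and on the fact that the shared core is kept. The step expected is a 1.3-fold higher number from compound 2 to compound 3 (0.10 log units; within the scatter), a small shift that should not exceed the scatter. For compound 3 the estimate is 2500 nM, with a likely range from 800 nM to 8000 nM.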

Compound 3, half-maximal inhibitory concentration: > 39800 nM
Compound 3 ended at the assay's limit; the forecaster's own chance of this, stated with the estimate: 10%; at least 15-fold (1.20 log units) between middle value and limit.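

In this assay compound 3 gives > 39800 nM, which is a limit of the assay and not a number. Methylsulfonyl in place of methoxy on this aromatic carbon gives an at least 19-fold higher number from compound 2 to compound 3 (1.29 log units; beyond the scatter), so the choice of group here matters greatly, which the level values of compound 1 and compound 2, with their differently placed methoxy groups, could not show. The step therefore marks a clear loss of inhibition, but its full size cannot be read: the limit of > 39800 nM in this assay, at which 1 of the 3 values shown sits.

A single exchange cannot tell which difference between methoxy and methylsulfonyl accounts for the loss, and no cause can be assigned from it. As far as these compounds go, it also remains open how an amine, a nitrile or a carboxylic acid on this carbon would behave, and whether methylsulfonyl would fare the same at the methoxy position of compound 1.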